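This account rests on a few compounds, and the source may have more. Where it says the series, first, only, none or still open, it means among the compounds named here.

Measured so far, all in one test:

Compound 1, `CCOC(=O)c1onc(-c2cn(-c3ccccc3)nc2-c2ccc(OC)cc2)c1C(=O)OCC`: 57.7%
Compound 2, `CCOC(=O)c1onc(-c2cn(-c3ccccc3)nc2-c2ccc(Cl)cc2)c1C(=O)OCC`: 55.3%
Compound 3, `COc1ccc(-c2nn(-c3ccccc3)cc2-c2cc(-c3ccccc3)on2)cc1`: 31%

The test is a functional assay on the whole organism (Abdomen, strain Swiss albino) with Mus musculus as the target, with stated times of 10 min and 5 min, at a dose of 30 mg/kg by the oral route; a higher number here means a stronger effect of the compound at the dose given, a lower number a weaker effect. Compound 1 and compound 2 share one core and differ in a single place: chloro in place of methoxy on an aromatic carbon. Between them this assay moves by a number 2.4 percentage points lower from compound 1 to compound 2 (within the scatter), so the two numbers cannot be told apart with confidence. Compound 3 is built on a different core, carrying only part of what compound 1 carries; the difference between the two cores is not broken down here. In this assay compound 3 stands lowest of the three, and its gap to compound 2 and to compound 1 is larger than the scatter of the test.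

Compound 4, `Clc1ccc(-c2nn(-c3ccccc3)cc2-c2cc(-c3ccccc3)on2)cc1`, has not yet been measured. It differs from compound 3 in one place: chloro in place of methoxy on an aromatic carbon. This is the same change that leads from compound 1 to compound 2, set on the same kind of aromatic carbon in each pair. Among the compounds with values here, the only guide to its effect is that earlier pair, where the step was a number 2.4 percentage points lower from compound 1 to compound 2 (within the scatter), a movement inside the usual scatter. On that basis the step from compound 3 to compound 4 is expected to be small as well, roughly a number 1 percentage points lower from compound 3 to compound 4 (within the scatter). The estimate for compound 4 in this assay is therefore 30%, with a likely range from 18% to 44%.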

Compound 4, a percentage reported as activity, at one dose (the size of the read-out at that dose, not a potency): 49%
The estimate for compound 4 lay 19 percentage points below the measured number; measured number outside the range, above it.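

In this assay, putting chloro in place of methoxy, the change from 4-methoxyphenyl to 4-chlorophenyl, gives a clear step on the core of compound 3: a number 18 percentage points higher from compound 3 to compound 4 (beyond the scatter). On the core of compound 1, the same change left the result indistinguishable within the scatter, so the size of this step does not carry over from one core to the other, and the two steps differ: the same change on two cores in this assay, a number 2.4 percentage points lower (within the scatter) from compound 1 to compound 2 and a number 18 percentage points higher (beyond the scatter) from compound 3 to compound 4, 20.4 percentage points apart, beyond the scatter of two such steps These two pairs show that the core matters to what this change does in this test, but they do not show which part of the core is responsible, why the two cores respond differently, or whether the same contrast would hold at another dose.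

The compounds shown carry only methoxy or chloro at this place on the aromatic ring, so it remains open how a methyl group, a fluoro group, an amine or a carboxylic acid would behave there on either core. On these data alone, it also remains open how much of the gap between the two cores comes from the two ethyl ester groups on the core of compound 1, since the change between the cores is not broken down into single steps.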